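A few compounds are considered here, and "the series" means these few. Any claim that something is new, unique, unknown or untested is made for them only; others in the source may bear on it.

Measured compounds:
- compound 1 `Cc1n[nH]c2ccc(-c3nc4cnc(N5CCN(C)CC5)cn4c3Nc3ccccc3Cl)cc12` — a functional assay on CWR22R cells (Homo sapiens) for inhibition, with a stated time of 120 h, tested at 10 uM; a higher number here means more inhibition at the concentration tested (going by the name of the read-out), a lower number less inhibition: "not determined" (no result reported)
- compound 2 `COc1ccc(Nc2c(-c3ccc4[nH]nc(C)c4c3)nc3cnc(N4CCN(C)CC4)cn23)cc1` — this assay: 0%
- compound 3 `Cc1n[nH]c2ccc(-c3nc4cnc(N5CCN(C)CC5)cn4c3Nc3ccc(Br)cc3Cl)cc12` — this assay: "not determined" (no result reported)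

Compound 1 stands on no number in this assay, and compound 3 likewise carries no number. The only figure in the set is that of compound 2, which in this assay gives 0%. For the measured compounds named here, no step between measured compounds is available, so nothing in the measured set tells how a change of this kind shifts the read-out.

Compound 4 `Cc1n[nH]c2ccc(-c3nc4cnc(N5CCN(C)CC5)cn4c3Nc3ccc(F)cc3Br)cc12` is the unmeasured analogue of compound 1. The change is 2-bromo-4-fluorophenyl in place of 2-chlorophenyl on a nitrogen on an aromatic ring. Going by the values given here, with no step to rest on and the one measured value being that of compound 2, no shift beyond the scatter is expected in either direction from a low read-out. Compound 4 is estimated to give 10% in this assay, with a range from 0% to 35%.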

Compound 4, a percentage reported as inhibition, at one concentration (the size of the read-out at that concentration, not a potency): 4.41%
Compound 4: the middle estimate sits 5.6 percentage points above what was measured, and the stated range covers the measured number.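

In this assay the position on a nitrogen on an aromatic ring now carries two groups with numbers, 2-bromo-4-fluorophenyl and 4-methoxyphenyl. The step reads a number 4.4 percentage points higher from compound 2 to compound 4 (within the scatter) so this exchange does not separate the two groups at this position. Nothing measured here bears on why.

Compound 1 and compound 3 carry no number, so the change from 2-chlorophenyl to 2-bromo-4-fluorophenyl cannot be read. Also open, from the compounds shown here alone, is whether a carboxylic acid or an aminomethyl group on this phenyl ring would give a read-out beyond the scatter.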